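This account rests on a few compounds, and the source may have more. Where it says the series, first, only, none or still open, it means among the compounds named here.

Measured so far in a functional assay on microsomes from liver (Rattus norvegicus) for inhibition; a higher number here means a weaker inhibitor, a lower number a stronger inhibitor:
- compound 1 `COc1ccc2c(c1)CC/C(=C\c1ccccc1Br)C2=O`: > 20000 nM (a limit of the assay, not a number)
- compound 2 `O=C1/C(=C/c2ccccc2Br)CCc2cc(O)ccc21`: 2400 nM

Among the measured compounds shown here, compound 2, at 2400 nM, holds the only actual number. Compound 3 `O=C1/C(=C/c2ccccc2-c2ccccc2)CCc2cc(O)ccc21` differs from it as follows: phenyl in place of bromo on an aromatic carbon. This is phenyl in place of bromo on an aromatic carbon, ortho to a large group. For the measured compounds named here, the one measured step, an at least 8.3-fold lower number from compound 1 to compound 2 (0.92 log units; beyond the scatter), is hydrogen in place of methyl on an oxygen on an aromatic ring. Compound 3 keeps that hydrogen, so the step does not bear directly on the new change. Going by the values given here, no measured step covers a change at the bromo position, so no direction is favoured and a shift beyond the scatter is not expected, though the uncertainty is wide. The expected step is a 1.0-fold higher number from compound 2 to compound 3 (0.02 log units; within the scatter). Compound 3 is estimated at 2500 nM, with an expected range of 500 nM to 12000 nM.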

Compound 3, half-maximal inhibitory concentration: > 20000 nM
Compound 3: only a limit was reported; the forecaster's own chance of this, stated with the estimate: 15%; at least 8.0-fold (0.90 log units) between middle value and limit.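

In this assay, the bromo position proves not to be indifferent to what it carries: phenyl in place of bromo on an aromatic carbon, ortho to a large group, gives an at least 8.3-fold higher number from compound 2 to compound 3 (0.92 log units; beyond the scatter). Compound 3 keeps the hydrogen on the aromatic oxygen, so that hydrogen alone does not secure a measurable number in this series. The step is a lower bound, and its full size cannot be read: the limit of > 20000 nM in this assay, at which 2 of the 3 values shown sit.

Bromo and phenyl are the only groups shown at this position, so it remains open whether the loss follows the larger group or the added ring. A methyl or chloro group would test size on a smaller scale, while an amine or a carboxylic acid on the added phenyl would show whether that ring can be accommodated at all.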